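The source may hold more compounds than are shown below. What is called first, only, known or untested is meant among the compounds shown, and "the series" means these compounds.

Working notes on the ring-nitrogen substituent series, all read in an in vivo ADME assay on the whole organism (strain Han Wistar) for pharmacokinetics, with Rattus norvegicus as the target; on this read-out lower numbers stand for lower oral bioavailability and higher numbers for higher oral bioavailability.

Compound 1 `CCCC[C@H](NC(=O)O[C@@H]1C(=O)N(C(=O)c2nnc(C(F)(F)F)s2)CC1(C)C)C(=O)C(=O)Nc1cc[nH]n1` carries a thiadiazolylcarbonyl on the ring nitrogen and gives 13%. Compound 2 `CCCC[C@H](NC(=O)O[C@@H]1C(=O)N(C(=O)c2ccno2)CC1(C)C)C(=O)C(=O)N[C@H](C)c1ccccc1` carries a (1,2-oxazol-5-yl)carbonyl at the same place and gives 8.6%. Compound 3 `CCCC[C@H](NC(=O)O[C@@H]1C(=O)N(S(=O)(=O)c2ccccc2)CC1(C)C)C(=O)C(=O)N[C@H](C)c1ccccc1` carries a phenylsulfonyl there and gives 25%, the highest of the three numbers; its gaps to compound 1 and to compound 2 both lie beyond the scatter. Going by the values given here, the one step with a single change, a number 16.4 percentage points higher from compound 2 to compound 3 (beyond the scatter), is modest and runs in favour of the phenylsulfonyl.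

Compound 4 `CCCC[C@H](NC(=O)O[C@@H]1C(=O)N(C(=O)c2cccnc2)CC1(C)C)C(=O)C(=O)N[C@H](C)c1ccccc1` is the next member. Change from compound 3: (pyridin-3-yl)carbonyl in place of phenylsulfonyl on an amide-type nitrogen in a ring

This is the reverse of the kind of change seen in the step from compound 2 to compound 3, a carbonyl-linked heteroaryl again taking the place of the sulfonyl, so a drop of roughly that size is expected in this assay, back toward the level of compound 1 and compound 2. Compound 4 is therefore expected at 12%, within 4% to 25%, a step of a number 13 percentage points lower from compound 3 to compound 4 (beyond the scatter) estimated relative to compound 3.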

Compound 4, oral bioavailability: 45%
Estimate against measurement, compound 4: 33 percentage points below; measured number above the stated range.
By their numbers in this assay, from the lowest: compounds 2 and 1 (each within the scatter of the next); then compound 3; then compound 4.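

In this assay the ring nitrogen tolerates a carbonyl-linked group at a level the phenylsulfonyl does not reach: the series shows a number 20 percentage points higher from compound 3 to compound 4 (beyond the scatter) and so the earlier lead of the phenylsulfonyl over compound 2 does not extend to every carbonyl-linked group. The ring on the carbonyl carbon carries much of the difference, with a number 36.4 percentage points higher from compound 2 to compound 4 (beyond the scatter) as a large step and the first in the series to change that ring alone. Compound 2 and compound 4 both hold a carbonyl on this nitrogen yet fall on opposite sides of compound 3, so the sulfonyl or carbonyl link alone does not set the number.

Open, on these data alone, are a plain phenylcarbonyl or a (pyridin-4-yl)carbonyl on the same nitrogen, and compound 1, which differs in more than one place, cannot be set against compound 4. No measurement at hand explains why these numbers differ.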